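A few compounds are considered here, and "the series" means these few. Any claim that something is new, unique, unknown or untested is made for them only; others in the source may bear on it.

Working notes on the series. The two measured compounds share one core, varied only on the aryloxy ring of the amide side. Compound 1 `Cc1cccc(OCC(=O)Nc2ccc(OCC(=O)O)c(F)c2)c1` and compound 2 `CC(C)c1ccc(OCC(=O)Nc2ccc(OCC(=O)O)c(F)c2)cc1` have been tested in a functional assay on CHO cells for agonist activity at Free fatty acid receptor 1 (Homo sapiens), read by FLIPR, tested at 100 nM; a higher number here means a stronger effect of the compound at the concentration tested, a lower number a weaker effect. In this assay compound 1 gives 45.4%. Compound 2 stands lowest of the two numbers, giving 11.8% in this assay; its nearest neighbour is compound 1, whose value lies higher by a margin beyond the usual scatter.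

The next compound, compound 3 `COc1ccc(OCC(=O)Nc2ccc(OCC(=O)O)c(F)c2)cc1`, is not yet measured. It differs from compound 2 in one place: methoxy in place of isopropyl on an aromatic carbon. For the measured compounds named here, no step between two measured compounds covers this exchange, so any expectation rests on the two values alone. The smaller substituent of compound 1 sits with the higher of the two values, so compound 3 is expected to move upward rather than downward; the step from compound 2 to compound 3 is estimated at a number 18.2 percentage points higher from compound 2 to compound 3 (beyond the scatter), likely beyond the scatter but with wide uncertainty. For compound 3 the estimate in this assay is 30%, with a range from 8% to 55%.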

Compound 3, a percentage reported as activity, at one concentration (the size of the read-out at that concentration, not a potency): 5.73%
Beside the measured number, compound 3's estimate is 24.3 percentage points above it; the measured number lies below the stated range.
By their numbers in this assay, from the lowest: compounds 3 and 2 (each within the scatter of the next); then compound 1.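

In this assay, methoxy in place of isopropyl on an aromatic carbon, para to a large group, comes out at a number 6.1 percentage points lower from compound 2 to compound 3 (within the scatter), so this exchange at this position does not separate compound 2 from compound 3. The large change appears instead with 4-methoxyphenyl in place of 3-methylphenyl on an oxygen on a saturated carbon, at a number 39.7 percentage points lower from compound 1 to compound 3 (beyond the scatter), a step that alters both the group and where it sits on the ring. No measurement is available that explains either step.

The compounds shown do not separate the effect of the group's identity from that of its place on the ring in this step. As far as these compounds go, it also remains open how an amine, a chlorine or a longer chain on the same aromatic carbon would read out in this assay.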